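From phenyl to phenoxy on compound 2

The source may hold more compounds than are shown below. What is called first, only, known or untested is meant among the compounds shown, and "the series" means these compounds.

Compound 1 `CCOC(=O)c1c(-c2cccc(Oc3ccccc3)c2)[nH]c2cc(OC)ccc2c1=O`: > 21500 nM
Compound 2 `CCOC(=O)c1c(-c2cccc(-c3ccccc3)c2)[nH]c2cc(O)ccc2c1=O`: > 21500 nM

Both results come from an ADME assay on BJ cells (Homo sapiens) for cytotoxicity, read by luminescence, with a stated time of 72 h; a lower number here means that less compound is needed, a higher number that more compound is needed for the effect. Compound 1 gives > 21500 nM, which is a limit of the assay and not a number. Compound 2 gives > 21500 nM, which is likewise only a limit. The picture so far is the limit of > 21500 nM in this assay, at which 2 of the 2 values shown sit, so compound 2 has no numerical value to stand on.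

Compound 3 `CCOC(=O)c1c(-c2cccc(Oc3ccccc3)c2)[nH]c2cc(O)ccc2c1=O` has not yet been measured. It carries phenoxy in place of phenyl on an aromatic carbon, meta to a large group: phenoxy in place of phenyl on an aromatic carbon. For the measured compounds named here, no measured step covers this change, so no shift beyond the usual scatter is expected in this assay, in either direction. The expected change is a step that the limit leaves unreadable from compound 2 to compound 3. For compound 3 the estimate is 25000 nM, with an expected range of 15000 nM to 45000 nM.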

Compound 3, half-maximal effective concentration: > 21500 nM
Compound 3: a limit, no number; the forecaster's own chance of this, stated with the estimate: 85%; the middle value is on the limit's open side.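

In this assay, for the compounds shown here, compound 3 gives > 21500 nM, which is a limit and not a number, so no step from compound 2 or compound 1 to compound 3 can be read. Whether phenoxy in place of phenyl, or hydrogen in place of methyl on the oxygen, changes the concentration needed stays open, because the compounds shown share one limit: the limit of > 21500 nM in this assay, at which 3 of the 3 values shown sit.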